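Moving a Methyl Around a Phenyl Amide

This account rests on a few compounds, and the source may have more. Where it says the series, first, only, none or still open, it means among the compounds named here.

Compound 1 `Cn1c(-c2ccccc2)cnc1NC(=O)c1ncc[nH]1` in a toxicity assay on THP-1 cells (Homo sapiens) for inhibition (on this read-out lower numbers stand for higher toxicity in this test and higher numbers for lower toxicity in this test), gives > 100000 nM, a limit of the assay rather than a number.
Compound 2 `Cn1c(-c2ccccc2)cnc1NC(=O)c1cccc(Cl)c1` in this assay gives > 50000 nM, also a limit.
Compound 3 `Cc1ccc(C(=O)Nc2ncc(-c3ccccc3)n2C)cc1` in this assay gives > 50000 nM, again a limit.

Compound 3 thus stands at the limit of > 50000 nM in this assay, at which 2 of the 3 values shown sit. Compound 1 sits at the limit of > 100000 nM in this assay, at which 1 of the 3 values shown sits. With every value a limit, the three steps a step that the two limits leave unreadable from compound 1 to compound 2, a step that the two limits leave unreadable from compound 1 to compound 3 and a step that the two limits leave unreadable from compound 2 to compound 3 are all unreadable in size. Compound 4 `Cc1cccc(C(=O)Nc2ncc(-c3ccccc3)n2C)c1` differs from compound 3 by 3-methylphenyl in place of 4-methylphenyl on a carbonyl carbon. Going by the values given here, no measured step bears readably on this change, so nothing beyond the scatter is expected in this assay. Compound 4 is expected to give 80000 nM, within 40000 nM to 200000 nM, most likely reported once more only as a limit. The expected step that the limit leaves unreadable from compound 3 to compound 4 is therefore no more than scatter.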

Compound 4, half-maximal cytotoxic concentration: > 50000 nM
Compound 4 gave a limit, no number; the forecaster's own chance of this, stated with the estimate: 85%; the middle value lies beyond the limit too.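

Going by these compounds alone, compound 4 gives only a limit in this assay, as do compound 1, compound 2 and compound 3, so no step to compound 4 can be read. The compounds shown leave open whether 3-methylphenyl and 4-methylphenyl differ at all in this assay.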